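This account rests on a few compounds, and the source may have more. Where it says the series, first, only, none or still open, it means among the compounds named here.

Measured in a physicochemical assay for lipophilicity, at pH 7.4; a lower number here means a more polar compound, a higher number a more lipophilic compound:
- Compound 1 `CCc1ccc(N(CC(C)C)S(=O)(=O)c2ccc3c(c2)C(=O)CC(C2CCN(C(=O)C4CCCC4)CC2)O3)cc1`: 5.13
- Compound 2 `CCc1ccc(N(CC(C)C)S(=O)(=O)c2ccc3c(c2)C(=O)CC(C2CCN(C(=O)OC(C)(C)C)CC2)O3)cc1`: 5.1
- Compound 3 `CCc1ccc(N(CC(C)C)S(=O)(=O)c2ccc3c(c2)C(=O)CC(C2CCOCC2)O3)cc1`: 4.21

Compound 3 holds the lowest of these three numbers, and compound 1 and compound 2 both stand higher, beyond the scatter. Compound 4 `CCc1ccc(N(CC(C)C)S(=O)(=O)c2ccc3c(c2)C(=O)CC(C2CCNCC2)O3)cc1` carries piperidin-4-yl in place of oxan-4-yl on a saturated ring carbon. Within the data shown here, the only measured step, a number 0.03 log units lower from compound 1 to compound 2 (within the scatter), exchanges cyclopentyl for tert-butoxy on a carbonyl carbon, so it does not test this change. The expectation therefore rests on the structural change alone, starting from compound 3 at 4.21, and it points to a lower number in this assay, beyond the scatter. The expected step is a number 1.01 log units lower from compound 3 to compound 4 (beyond the scatter). Compound 4 is estimated at 3.2, with an expected range of 2.4 to 4.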

Compound 4, distribution coefficient: 2.21
Beside the measured number, compound 4's estimate is 0.99 log units above it; the whole stated range lies above it.
By their numbers in this assay, from the lowest: compound 4; then compound 3; then compounds 2 and 1 (each within the scatter of the next).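

In this assay, piperidin-4-yl in place of oxan-4-yl on this saturated ring carbon gives a number 2.00 log units lower from compound 3 to compound 4 (beyond the scatter) and is the only change shown in the ring atom at this position. Hydrogen in place of tert-butoxycarbonyl on the ring amine nitrogen gives a number 2.89 log units lower from compound 2 to compound 4 (beyond the scatter) and hydrogen in place of cyclopentylcarbonyl gives a number 2.92 log units lower from compound 1 to compound 4 (beyond the scatter) while the exchange between those two groups gives only a number 0.03 log units lower from compound 1 to compound 2 (within the scatter) on the same nitrogen. Nothing available explains the size of these steps.

On these data alone, it remains open how a methyl or acetyl group on that nitrogen would read. As far as these compounds go, an open-chain amine on the same ring carbon also remains open.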